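This account rests on a few compounds, and the source may have more. Where it says the series, first, only, none or still open, it means among the compounds named here.

Compound 1 `CCOC(=O)/C(F)=C(C)/C=C/C=C(C)/C=C/c1c(C)cc(OC)c(C)c1C` and compound 2 `CCOC(=O)/C=C(C)/C(F)=C/C=C(C)/C=C/C1=C(C)CCCC1(C)C` have both been tested in a functional assay on the whole organism (strain Hart Swiss) with Mus musculus as the target, with stated times of 5 days and 2 weeks, at a dose of 10 mg/kg by the intraperitoneal route; on this read-out higher numbers stand for a stronger effect at the one dose given and lower numbers for a weaker effect. In this assay compound 1 gives 37%, and compound 2 gives 33%; these two numbers sit within the scatter of each other, so compound 1 cannot be set apart from compound 2 on them. Compound 3 `CCNC(=O)/C=C(C)/C=C/C=C(C)/C=C/c1c(C)cc(OC)c(C)c1C` is not yet measured. It differs from compound 1 in one place: a group of 8 heavy atoms (6 carbon, 1 nitrogen, 1 oxygen; no ring) in place of a group of 9 heavy atoms (6 carbon, 2 oxygen, 1 fluorine; no ring), on a double-bonded chain carbon bound to a double-bonded chain carbon. Within the data shown here, no measured pair of compounds shows this change, so the size of its effect is unknown. The expected step is a number 7 percentage points lower from compound 1 to compound 3 (within the scatter), small and, if anything, downward, hardly beyond the scatter. In this assay compound 3 is estimated at 30%, between 10% and 60%.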

Compound 3, a percentage reported as activity, at one dose (the size of the read-out at that dose, not a potency): 23%
Estimate against measurement, compound 3: 7 percentage points above; low and high end bracket the measured number.
By their numbers in this assay, from the lowest: compounds 3, 2 and 1 (each within the scatter of the next, the first and the last beyond it).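

In this assay, among these compounds, replacing the group of 9 heavy atoms with the group of 8 heavy atoms, on a double-bonded chain carbon bound to a double-bonded chain carbon, gives a number 14 percentage points lower from compound 1 to compound 3 (beyond the scatter) and is the first readable step at this position. The entering group also carries 1 hydrogen-bond donor where the leaving group has 0, yet no measurement explains the step. The compounds shown leave open whether losing the fluorine or gaining the ethyl amide carries the step. Going by these compounds, an ethyl ester without fluorine would separate the two, and a carboxylic acid here remains untested in this set.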